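A few compounds are considered here, and "the series" means these few. Any claim that something is new, unique, unknown or untested is made for them only; others in the source may bear on it.

Measured compounds:
- compound 1, `CCCCCCCCNC(=O)[C@@H](NC(=O)c1cccs1)[C@@H](C)O`, giving 149000 nM in a functional assay on HepG2 cells (Homo sapiens) for cytotoxicity, read by MTT assay, with a stated time of 48 h; a higher number here means a weaker inhibitor, a lower number a stronger inhibitor
- compound 2, `CCCCCCCCCCCCNC(=O)[C@@H](NC(=O)c1cccs1)[C@@H](C)O`, giving 30100 nM in this assay
- compound 3, `CCCCCCCCCCCCCCNC(=O)[C@@H](NC(=O)c1cccs1)[C@@H](C)O`, giving 88400 nM in this assay

All three share one core and differ only in the length of the chain on the amide nitrogen. Compound 3 and compound 1 lie within the usual scatter of each other, as a 1.7-fold lower number from compound 1 to compound 3 (0.23 log units; within the scatter) shows, whereas compound 2 stands apart: a 2.9-fold higher number from compound 2 to compound 3 (0.47 log units; beyond the scatter) and a 5.0-fold lower number from compound 1 to compound 2 (0.69 log units; beyond the scatter) are both beyond the scatter.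

Compound 4, `C/C=C/C=C/C(=O)N[C@H](C(=O)NCCCCCCCCCCCCCC)[C@@H](C)O`, keeps the chain of compound 3 and changes the other end of the core: penta-1,3-dien-1-yl in place of thiophen-2-yl on a carbonyl carbon. For the measured compounds named here, none of the measured steps touches this part of the molecule, so there is nothing here that shows how swapping the ring for an open chain affects this assay. With that, the number for compound 4 is expected to stay near that of compound 3, with the step of a 1.3-fold lower number from compound 3 to compound 4 (0.10 log units; within the scatter) as a best guess and a wide range around it. Compound 4 is therefore estimated at 70000 nM, between 15000 nM and 300000 nM.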

Compound 4, half-maximal inhibitory concentration: > 400000 nM
Compound 4 ended at the assay's limit; the forecaster's own chance of this, stated with the estimate: 10%; middle value at least 5.7-fold (0.75 log units) away from the limit.
By their numbers in this assay, from the lowest: compound 2; then compounds 3 and 1 (each within the scatter of the next). At a limit, above all of these: compound 4.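

Compound 4 gives > 400000 nM in this assay, which is a limit of the assay and not a number. Putting penta-1,3-dien-1-yl in place of thiophen-2-yl on the carbonyl carbon gives an at least 4.5-fold higher number from compound 3 to compound 4 (0.65 log units; beyond the scatter), so the group at this end of the shared core, which none of the chain steps touched, clearly matters here, and the open chain with its two double bonds gives the weaker inhibitor. The true size of this step stays unknown, because the value of compound 4 sits at a limit: the limit of > 400000 nM in this assay, at which 1 of the 4 values shown sits.

From the compounds shown here alone, with a single swap at this position, it remains open whether losing the ring or the sulfur counts more; a phenyl ring or a saturated pentyl chain in the same place would help to separate the two. Going by these compounds, it is also open whether the same swap acts alike on the shorter chain of compound 2.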